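Adding a methoxy group to a phenyl of compound 1

The compounds below may be only part of what the source reports. "The series", "measured", "known", "first", "only" and "open" are said of these compounds alone.

Compound 1 `Brc1ccc2[nH]c(-c3cn(-c4ccccc4)nc3-c3ccccc3)nc2c1` gives 1760 nM
Compound 2 `COc1ccc2[nH]c(-c3cn(-c4ccccc4)nc3-c3ccccc3)nc2c1` gives 2870 nM
Compound 3 `FC(F)(F)c1ccc2[nH]c(-c3cn(-c4ccccc4)nc3-c3ccccc3)nc2c1` gives 1920 nM

All three values come from a functional assay on HeLa cells (Homo sapiens) for antiproliferative activity, read by MTT assay, with a stated time of 48 h (a higher number here means a weaker inhibitor, a lower number a stronger inhibitor), and sit close together. For the measured compounds named here, compound 1 has no step to compound 2 or compound 3 that leaves the usual scatter, so the three stand level.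

Compound 4 `COc1ccc(-c2nn(-c3ccccc3)cc2-c2nc3cc(Br)ccc3[nH]2)cc1` keeps the bromo group of compound 1 and differs elsewhere: methoxy in place of hydrogen on an aromatic carbon, which is methoxy in place of hydrogen on an aromatic carbon, or phenyl to 4-methoxyphenyl.

The measured steps bear on this only indirectly, since each one swaps the group on the shared core and none touches this phenyl. The step of a 1.6-fold higher number from compound 1 to compound 2 (0.21 log units; within the scatter) stays within the scatter, as do a 1.1-fold higher number from compound 1 to compound 3 (0.04 log units; within the scatter) and a 1.5-fold lower number from compound 2 to compound 3 (0.17 log units; within the scatter). These compounds therefore show a flat picture at one site and give no direct guide to the new one. Any direction remains open, so the range must stay wide.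

Starting from compound 1 at 1760 nM, no change beyond the scatter is expected.

The expected step is a 1.0-fold lower number from compound 1 to compound 4 (0.02 log units; within the scatter), with neither direction favoured.

For compound 4 the estimated value is 1700 nM, with an expected range from 700 nM to 4000 nM.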

Compound 4, half-maximal inhibitory concentration: 1060 nM
Beside the measured number, compound 4's estimate is 1.6-fold (0.21 log units) above it; the measured number falls inside the stated range.
By their numbers in this assay, from the lowest: compounds 4, 1, 3 and 2 (each within the scatter of the next, the first and the last beyond it).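

For the compounds shown here, the step from phenyl to 4-methoxyphenyl in this assay is a 1.7-fold lower number from compound 1 to compound 4 (0.22 log units; within the scatter) and gives the first direct reading at this position, since the earlier steps changed only the group on the shared core. Compound 4 and compound 1 stand level, so this position accepts a methoxy group in place of hydrogen, with the bromo group kept, without a change that can be told from ordinary repeat variation. Together with the earlier steps, this leaves the picture flat at both sites in the compounds shown, although a single step says little about the position as a whole. No measurement here offers an explanation for this result.

The compounds shown leave open whether an amine, a carboxylic acid or a longer chain such as butoxy at this same place would also stand level with compound 1, or would instead shift the number beyond the scatter. They also leave open whether the 4-methoxyphenyl change would read the same with methoxy or trifluoromethyl in place of the bromo group on the shared core.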